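The source may report more compounds than this note shows. Statements on the series, on what has been measured and on what is new or still open speak of the compounds shown alone.

In a functional assay on HL-60 cells (Homo sapiens) for antiproliferative activity, read by sulforhodamine B assay, with a stated time of 72 h (a lower number here means a stronger inhibitor, a higher number a weaker inhibitor), compound 2 (`CCN1C(=O)CS/C1=N/Nc1nncc2ccccc12`) gives 3 nM, level with compound 1 (`O=C1CS/C(=N/Nc2nncc3ccccc23)N1c1ccccc1`) at 3 nM. These two share the lowest number in the series, while compound 3 (`O=S(=O)(Nc1nccs1)c1ccc(Nc2nncc3ccccc23)cc1`) lies clearly higher at 77 nM. Compound 4 (`O=C1CS/C(=N/Nc2nncc3ccccc23)N1`) differs from compound 2 by a single change: hydrogen in place of ethyl on an amide-type nitrogen in a ring. Among the compounds with values here, the one measured step at this nitrogen shows no change at the digits printed from compound 1 to compound 2 (within the scatter), with ethyl in place of phenyl. Within the data shown here, no measured compound carries hydrogen there, so this is an extrapolation. In this assay, a small rise or none beyond the scatter is expected. The expected step is a 1.7-fold higher number from compound 2 to compound 4 (0.22 log units; within the scatter). Compound 4 is estimated at 5 nM, with an expected range of 2 nM to 25 nM.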

Compound 4, half-maximal inhibitory concentration: 4 nM
Compound 4: the middle estimate sits 1.3-fold (0.10 log units) above what was measured; the range from low to high includes it.
By their numbers in this assay, from the lowest: compounds 1, 2 and 4 (each within the scatter of the next); then compound 3.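

In this assay hydrogen on the amide-type nitrogen gives a 1.3-fold higher number from compound 2 to compound 4 (0.12 log units; within the scatter) and a 1.3-fold higher number from compound 1 to compound 4 (0.12 log units; within the scatter) so hydrogen, ethyl and phenyl do not separate at this position. The earlier compounds shown here compared only ethyl and phenyl; this result shows that a low number here does not depend on a carbon group on this nitrogen. Nothing at hand gives a reason for this tolerance.

As far as these compounds go, whether a carboxylic acid or a longer chain ending in an amine on this nitrogen would stay level remains open. The flat picture rests on three compounds in one cell line.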